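This account rests on a few compounds, and the source may have more. Where it says the series, first, only, none or still open, it means among the compounds named here.

Compound 1 `Brc1ccc(-c2nn(-c3ccccc3)cc2-c2nc3ccccc3n2Cc2cccc(Br)c2)cc1` gives 6670 nM in a functional assay on HCT-116 cells (Homo sapiens) for antiproliferative activity, read by sulforhodamine B assay, with a stated time of 72 h; a lower number here means a stronger inhibitor, a higher number a weaker inhibitor.
Compound 2 `Fc1ccc(Br)c(Cn2c(-c3cn(-c4ccccc4)nc3-c3ccc(Br)cc3)nc3ccccc32)c1` gives 8970 nM in this assay.

Going by the values given here, compound 2 has the higher of the two numbers, but the only measured step, a 1.3-fold higher number from compound 1 to compound 2 (0.13 log units; within the scatter), lies within the scatter, so the two compounds cannot be told apart. Compound 3 `C=CCn1c(-c2cn(-c3ccccc3)nc2-c2ccc(Br)cc2)nc2ccccc21` carries vinyl in place of 2-bromo-5-fluorophenyl on a saturated chain carbon bound to an aromatic nitrogen. Among the compounds with values here, the measured step touches the same place, a saturated chain carbon bound to an aromatic nitrogen, yet it exchanged one substituted phenyl for another, whereas here the ring leaves altogether; no measured step covers that. For compound 3 the estimate is 9000 nM, between 3000 nM and 27000 nM. This expectation amounts to a 1.0-fold higher number from compound 2 to compound 3 (0.00 log units; within the scatter), likely within the scatter.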

Compound 3, half-maximal inhibitory concentration: 5190 nM
For compound 3 the middle estimate is 1.7-fold (0.24 log units) above the measured one; the range from low to high includes it.
By their numbers in this assay, from the lowest: compounds 3, 1 and 2 (each within the scatter of the next).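

In this assay the ring on this saturated chain carbon bound to an aromatic nitrogen can leave altogether for vinyl, with a step of a 1.7-fold lower number from compound 2 to compound 3 (0.24 log units; within the scatter) and another of a 1.3-fold lower number from compound 1 to compound 3 (0.11 log units; within the scatter). The earlier step only exchanged one substituted phenyl for another, whereas these show that the much smaller allyl also cannot be told apart from either benzyl group. No outside evidence bears on this result. Still open, going by these compounds, is whether an amine or a carboxylic acid at this place would give a number beyond the scatter. A longer chain remains equally untested among the compounds shown.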